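The source may report more compounds than this note shows. Statements on the series, on what has been measured and on what is new or still open speak of the compounds shown alone.

Of the compounds shown here, three that share one core have been measured in an assay on isolated protein for inhibition of Indoleamine 2,3-dioxygenase 1 (Homo sapiens), read by fluorescence, with a stated time of 60 min; on this read-out higher numbers stand for weaker inhibition and lower numbers for stronger inhibition. Compound 1 `CS(=O)(=O)NNc1nonc1/C(=N/O)Nc1ccc(F)c(Br)c1` gives 609 nM. Compound 2 `NS(=O)(=O)NNc1nonc1/C(=N/O)Nc1ccc(F)c(Br)c1` gives 218 nM. Compound 3 `CN(C)S(=O)(=O)CCNc1nonc1/C(=N/O)Nc1ccc(F)c(Br)c1` gives 105 nM. Among these three numbers compound 2 stands second highest, with compound 3 nearest to it and compound 1 furthest away; the steps of a 2.8-fold lower number from compound 1 to compound 2 (0.45 log units; beyond the scatter) and a 2.1-fold lower number from compound 2 to compound 3 (0.32 log units; beyond the scatter) set it apart from both.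

Compound 4 `O=S(=O)(CCNc1nonc1/C(=N/O)Nc1ccc(F)c(Br)c1)N1CCC1` has not yet been measured. It differs from compound 2 in one place: 2-((azetidin-1-yl)sulfonyl)ethyl in place of sulfamoylamino on a nitrogen on an aromatic ring. The step that bears most directly on this change is a 2.1-fold lower number from compound 2 to compound 3 (0.32 log units; beyond the scatter), where the same sulfamoylamino group was replaced by a closely related sulfonyl-bearing two-carbon chain; the step of a 5.8-fold lower number from compound 1 to compound 3 (0.76 log units; beyond the scatter) points the same way. A similar, modest drop in the number is therefore expected for compound 4, giving an expected step of a 2.2-fold lower number from compound 2 to compound 4 (0.34 log units; beyond the scatter). Compound 4 is estimated at 100 nM, with a range from 40 nM to 250 nM.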

Compound 4, half-maximal inhibitory concentration: 191 nM
Beside the measured number, compound 4's estimate is 1.9-fold (0.28 log units) below it; low and high end bracket the measured number.
By their numbers in this assay, from the lowest: compounds 3, 4 and 2 (each within the scatter of the next, the first and the last beyond it); then compound 1.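

In this assay the 2-((azetidin-1-yl)sulfonyl)ethyl group, which carries a four-membered ring and no hydrogen-bond donors, can stand in place of sulfamoylamino on this nitrogen with a result that stays within the scatter (a 1.1-fold lower number from compound 2 to compound 4 (0.06 log units; within the scatter)). Among the compounds shown here, putting azetidin-1-yl in place of dimethylamino on the sulfonyl sulfur also stays within the scatter (a 1.8-fold higher number from compound 3 to compound 4 (0.26 log units; within the scatter)), so the earlier compounds' sulfonyl-bearing ethyl chain tolerates this ring closure as far as this read-out can tell. Only the comparison with methanesulfonamido lies beyond the scatter, and it is modest (a 3.2-fold lower number from compound 1 to compound 4 (0.50 log units; beyond the scatter)).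

No measurement here offers an explanation for these numbers. The compounds shown leave open how a larger ring such as piperidine on the sulfonyl sulfur, or a carboxylic acid in place of the sulfonyl group on the ethyl chain, would read in this assay.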